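The source may hold more compounds than are shown below. What is called first, only, known or untested is meant among the compounds shown, and "the series" means these compounds.

Measured so far:
compound 1, `O=C1C[C@H](O)C[C@@H](/C=C/c2cnc3c(Sc4ccc(F)cc4)c(Sc4ccc(F)cc4)c(F)cc3c2Sc2ccc(F)cc2)O1`: 11900 nM
compound 2, `COc1cccc(Sc2cc3ncc(/C=C/[C@@H]4C[C@@H](O)CC(=O)O4)c(Sc4cccc(OC)c4)c3cc2F)c1`: 3640 nM

Both numbers come from an assay (strain Holtzman-Sprague-Dawley) for inhibition of 3-hydroxy-3-methylglutaryl-coenzyme A reductase (Rattus norvegicus), with a stated time of 30 min; a higher number here means a weaker inhibitor, a lower number a stronger inhibitor. Compound 1 gives 11900 nM in this assay, the higher of the two numbers and so the weaker inhibitor of the pair. Compound 2 gives 3640 nM in this assay, a lower number, and the gap between the two lies beyond the usual scatter of repeated measurements.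

The next compound is compound 3, `O=C1C[C@H](O)C[C@@H](/C=C/c2cnc3cc(Sc4ccc(F)cc4)c(F)cc3c2Sc2ccc(F)cc2)O1`, which has not yet been measured. It is derived from compound 1 by a single change: hydrogen in place of (4-fluorophenyl)sulfanyl on an aromatic carbon, one of the three such groups on the shared core of compound 1 being taken away. For the measured compounds named here, no step between measured compounds shows this change on its own, so its effect can only be estimated. The step of a 2.0-fold lower number from compound 1 to compound 3 (0.30 log units; within the scatter) is expected to be modest and toward a lower number, and it may well fall within the scatter. Compound 3 is expected to give about 6000 nM, within a range from 1800 nM to 20000 nM.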

Compound 3, half-maximal inhibitory concentration: 38900 nM
Compound 3: middle estimate off by 6.5-fold (0.81 log units), on the low side; measured number above the stated range.
By their numbers in this assay, from the lowest: compound 2; then compound 1; then compound 3.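

In this assay the step of a 3.3-fold higher number from compound 1 to compound 3 (0.51 log units; beyond the scatter) shows that the (4-fluorophenyl)sulfanyl group on this aromatic carbon, ortho to a further (4-fluorophenyl)sulfanyl group, is not dispensable: with hydrogen in its place the inhibitor is weaker, by a margin beyond the usual scatter. For the compounds shown here, this is the first reading of a single change on the shared core, and it rests on one pair of compounds, so it describes this position in this setting and nothing wider. Nothing measured here explains the rise in the number.

The compounds shown leave open whether the whole (4-fluorophenyl)sulfanyl group is needed on this carbon, or whether something much smaller, such as a methyl group, a chlorine atom or an amine, would serve as well. They also leave open whether a phenoxy group, with oxygen in place of the sulfur link, would behave the same way, and whether taking away either of the other two (4-fluorophenyl)sulfanyl groups would shift the number in the same direction.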